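Alkyl Ether Versus Free Phenol in an Electroshock Screen

The source may report more compounds than this note shows. Statements on the series, on what has been measured and on what is new or still open speak of the compounds shown alone.

Measured compounds:
Compound 1 `CCCOc1cccc(/C=N/n2c(-c3ccccc3)nc3ccccc3c2=O)c1`: 30 mg/kg
Compound 2 `O=c1c2ccccc2nc(-c2ccccc2)n1/N=C/c1cccc(O)c1`: 100 mg/kg

Two compounds share the same core and differ only at an oxygen on an aromatic ring. In a functional assay on the whole organism (strain albino CF-1) with Mus musculus as the target, in the maximal electroshock model, with a stated time of 4 h (on this read-out higher numbers stand for an effect only at larger amounts of compound and lower numbers for an effect already at smaller amounts), compound 1 gives 30 mg/kg, while compound 2 gives 100 mg/kg. Compound 2 therefore stands at the highest number of the two measured, and the step of a 3.3-fold higher number from compound 1 to compound 2 (0.52 log units; beyond the scatter) lies beyond the scatter.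

Compound 3 `CC(C)Oc1cccc(/C=N/n2c(-c3ccccc3)nc3ccccc3c2=O)c1` has not been measured. It differs from compound 2 by isopropyl in place of hydrogen on an oxygen on an aromatic ring; cut one bond further out, the change reads hydroxy to isopropoxy. Going by the values given here, the one measured step that bears on this is the reverse of a 3.3-fold higher number from compound 1 to compound 2 (0.52 log units; beyond the scatter), where a propyl on the same oxygen went with a lower number in this assay. Compound 3 carries an isopropyl there instead, so the expected step is a 2.9-fold lower number from compound 2 to compound 3 (0.46 log units; beyond the scatter), toward a lower number. The estimate for compound 3 is 35 mg/kg, within the range 15 mg/kg to 80 mg/kg.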

Compound 3, minimum effective dose: 300 mg/kg
The estimate for compound 3 lay 8.6-fold (0.93 log units) below the measured number; the whole stated range lies below it.
By their numbers in this assay, from the lowest: compound 1; then compound 2; then compound 3.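

At this oxygen on the aromatic ring, putting an alkyl group in place of hydrogen does not lower the number by itself: in this assay, isopropyl gives a 3.0-fold higher number from compound 2 to compound 3 (0.48 log units; beyond the scatter), the opposite direction to the one seen with propyl. The choice between the two ethers matters even more, since isopropyl in place of propyl gives a 10-fold higher number from compound 1 to compound 3 (1.00 log units; beyond the scatter). The free phenol, compound 2, therefore sits between the two ethers, so across these three compounds, going from hydroxy to an ether has no single direction.

On these data alone, whether a smaller group such as methyl or a longer chain such as butyl on this oxygen would behave more like propyl or like isopropyl remains open. Nothing shown here gives a reason for the gap between the two ethers.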